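The compounds below may be only part of what the source reports. "The series", "measured", "known", "first", "only" and "open" are said of these compounds alone.

Compound 1 `Cn1ncc2c(=O)n(-c3ccccc3)c(SC(C)(C)c3ccccc3)nc21` was tested in an assay on isolated protein for inhibition of Retinaldehyde dehydrogenase 3 (Homo sapiens) (a lower number here means a stronger inhibitor, a higher number a weaker inhibitor), where compound 1 gives 1390 nM. Of the two numbers in hand this is the higher one; compound 2 `CC(Sc1nc2nn(C3COC3)cc2c(=O)n1-c1ccccc1)c1ccccn1` gives 480 nM in this assay, a lower number whose gap from compound 1 lies beyond the scatter. Compound 3 `CC(Sc1nc2c(cnn2C)c(=O)n1-c1ccccc1)c1cccc(O)c1` differs from compound 1 in one place: a group of 9 heavy atoms (8 carbon, 1 oxygen; one six-membered aromatic ring of carbon only) in place of a group of 9 heavy atoms (9 carbon; one six-membered aromatic ring of carbon only), on a sulfur. For the measured compounds named here, no measured pair shows this exact change. The step is expected to be small and toward a lower number, estimated as a 1.9-fold lower number from compound 1 to compound 3 (0.27 log units; within the scatter). Compound 3 is therefore estimated at 750 nM, within a range from 250 nM to 2200 nM.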

Compound 3, half-maximal inhibitory concentration: 91 nM
For compound 3 the middle estimate is 8.2-fold (0.92 log units) above the measured one; the whole stated range lies above it.
By their numbers in this assay, from the lowest: compound 3; then compound 2; then compound 1.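

In this assay, replacing 1-methyl-1-phenylethyl on the sulfur gives a 15-fold lower number from compound 1 to compound 3 (1.18 log units; beyond the scatter), so this position responds strongly even when the count of heavy atoms stays the same. The entering group swaps one carbon for an oxygen and brings 1 hydrogen-bond donor and 1 hydrogen-bond acceptor, where the leaving group has neither. No available measurement explains the step. As far as these compounds go, it remains open whether the hydroxyl alone carries this step, and whether a methoxy or an amine in its place would do the same.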